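Moving the pyridine nitrogen in compound 1

This account rests on a few compounds, and the source may have more. Where it says the series, first, only, none or still open, it means among the compounds named here.

Compound 1 `Fc1cccc(Nc2nccc(-c3ccccn3)n2)c1` gives 1000 nM in a functional assay for inhibition, with Homo sapiens as the target (on this read-out lower numbers stand for stronger inhibition and higher numbers for weaker inhibition), the second highest of three numbers. Compound 2 `Nc1cccc(Nc2nccc(-c3ccccn3)n2)c1` gives 300 nM and compound 3 `CCOC(=O)c1cccc(Nc2nccc(-c3ccccn3)n2)c1` gives 3000 nM; the step of a 3.3-fold lower number from compound 1 to compound 2 (0.52 log units; beyond the scatter) and the step of a 3.0-fold higher number from compound 1 to compound 3 (0.48 log units; beyond the scatter) both change the substituent on the aniline ring. Compound 4 `Fc1cccc(Nc2nccc(-c3ccncc3)n2)c1` differs from compound 1 elsewhere: pyridin-4-yl in place of pyridin-2-yl on an aromatic carbon. Among the measured compounds shown here, no measured step touches this position, so the measured steps offer no direct guide. A modest weakening is therefore expected as a cautious guess, with a wide range, giving a 2.5-fold higher number from compound 1 to compound 4 (0.40 log units; beyond the scatter). Compound 4 is estimated at 2500 nM, expected between 800 nM and 8000 nM.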

Compound 4, half-maximal inhibitory concentration: 700 nM
Compound 4: the middle estimate sits 3.6-fold (0.55 log units) above what was measured, and the stated range ends above it.
By their numbers in this assay, from the lowest: compound 2; then compounds 4 and 1 (each within the scatter of the next); then compound 3.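

Among the compounds shown here, the step of a 1.4-fold lower number from compound 1 to compound 4 (0.15 log units; within the scatter) in this assay gives the first reading at this position: with pyridin-4-yl in place of pyridin-2-yl, the number stays within the scatter. Moving the pyridine nitrogen therefore leaves no readable mark on the core of compound 1, whereas each earlier substituent change moved the number beyond the scatter. Nothing at hand explains this result.

Still open, from the compounds shown here alone, is whether pyridin-4-yl would behave the same way alongside the amino group of compound 2. Also open, going by these compounds, is how pyridin-3-yl or a plain phenyl ring would read at this position.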